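The source may report more compounds than this note shows. Statements on the series, on what has been measured and on what is new or still open speak of the compounds shown alone.

Measured so far in an ADME assay on cells for inhibition of cytochrome P450 11B1, mitochondrial (Homo sapiens), read by HPLC, with a stated time of 60 min; a higher number here means a weaker inhibitor, a lower number a stronger inhibitor:

- compound 1 `Cc1ncncc1-c1nc2cc(F)c(F)cc2n1C1CC1`: 4160 nM
- compound 2 `CCc1ncncc1-c1nc2cc(F)c(F)cc2n1C1CC1`: 3330 nM
- compound 3 `CN(C)c1ncncc1-c1nc2cc(F)c(F)cc2n1C1CC1`: 4630 nM

Compound 3 gives the highest of the three numbers, yet its gaps to compound 1 and to compound 2 are both within the scatter, so the three compounds stand level and none can be called the weaker or the stronger inhibitor. The steps among them are small: a 1.2-fold lower number from compound 1 to compound 2 (0.10 log units; within the scatter), a 1.1-fold higher number from compound 1 to compound 3 (0.05 log units; within the scatter) and a 1.4-fold higher number from compound 2 to compound 3 (0.14 log units; within the scatter). The last two exchange the group on the same aromatic carbon that is changed next.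

Compound 4 `Fc1cc2nc(-c3cncnc3NCCC(F)(F)F)n(C3CC3)c2cc1F` differs from compound 3 by (3,3,3-trifluoropropyl)amino in place of dimethylamino on an aromatic carbon. The group that enters is larger than any tried so far at this carbon, and carries a hydrogen-bond donor where none stood before, so the two steps that bear on it, both within the scatter, reach only part of the way. No direction beyond the scatter is supported by the data. The step from compound 3 to compound 4 is therefore expected to be small, a 1.2-fold lower number from compound 3 to compound 4 (0.06 log units; within the scatter), with the range widened for the unprecedented group. Compound 4 is expected to give 4000 nM in this assay, between 1300 nM and 12000 nM.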

Compound 4, half-maximal inhibitory concentration: 378 nM
The estimate for compound 4 lay 11-fold (1.02 log units) above the measured number; measured number below the stated range.
By their numbers in this assay, from the lowest: compound 4; then compounds 2, 1 and 3 (each within the scatter of the next).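

In this assay, the aromatic carbon where methyl, ethyl and dimethylamino stood level is not indifferent to its substituent: (3,3,3-trifluoropropyl)amino gives a 12-fold lower number from compound 3 to compound 4 (1.09 log units; beyond the scatter), alongside an 11-fold lower number from compound 1 to compound 4 (1.04 log units; beyond the scatter) and an 8.8-fold lower number from compound 2 to compound 4 (0.94 log units; beyond the scatter). This single change adds heavy atoms, fluorine and a hydrogen-bond donor together, so the step cannot be assigned to any one of them. No measurement at hand accounts for the step.

A propylamino group would separate the contribution of the fluorines from that of the chain, while methylamino would test a short chain that keeps the amine hydrogen. A (3,3,3-trifluoropropyl)(methyl)amino group would show whether the step survives without that hydrogen.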